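The source may report more compounds than this note shows. Statements on the series, on what has been measured and on what is new or still open speak of the compounds shown alone.

Compound 1 `O=[N+]([O-])c1ccc(CN2CCC(n3cc(CC(OCc4cc(-c5ccc(Br)cc5)no4)c4ccc(Br)cc4)nn3)CC2)cc1` — in a functional assay on HCT-116 cells (Homo sapiens) for cytotoxicity, with a stated time of 48 h (on this read-out higher numbers stand for weaker inhibition and lower numbers for stronger inhibition), compound 1 gives > 25000 nM, which is a limit of the assay.
Compound 2 `O=[N+]([O-])c1ccc(CN2CCC(n3cc(CC(OCc4cc(-c5cccc(Br)c5)no4)c4ccc(Br)cc4)nn3)CC2)cc1` — in this assay compound 2 gives > 25000 nM, which is a limit of the assay.
Compound 3 `N#Cc1cccc(-c2cc(COC(Cc3cn(C4CCN(Cc5ccc([N+](=O)[O-])cc5)CC4)nn3)c3ccc(Br)cc3)on2)c1` — in this assay compound 3 gives > 25000 nM, which is a limit of the assay.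

Compound 3 therefore stands at the same place as every other measured compound in the series: all three values sit at the limit of > 25000 nM in this assay, at which 3 of the 3 values shown sit, and none of them is a number. The steps between the measured compounds, a step that the two limits leave unreadable from compound 1 to compound 2, a step that the two limits leave unreadable from compound 1 to compound 3 and a step that the two limits leave unreadable from compound 2 to compound 3, are all unreadable in size for the same reason.

Compound 4 `O=[N+]([O-])c1ccc(CN2CCC(n3cc(CC(OCc4cc(-c5ccccc5Br)no4)c4ccc(Br)cc4)nn3)CC2)cc1` is the next variation of the same kind: 2-bromophenyl in place of 3-cyanophenyl on an aromatic carbon. The measured steps bear on it only in that exchanging bromophenyl and cyanophenyl groups at this position of the shared core has so far produced nothing measurable. No readable step is therefore expected in this assay; the step that the limit leaves unreadable from compound 3 to compound 4 is expected to remain within the limit. For compound 4 the estimate is 40000 nM, with a range from 25000 nM to 100000 nM.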

Compound 4, half-maximal inhibitory concentration: > 25000 nM
Compound 4: only a limit was reported; the forecaster's own chance of this, stated with the estimate: 85%; the middle value does not contradict the limit.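

In this assay, among these compounds, compound 4 gives > 25000 nM, which is a limit and not a number, so no step to it from compound 1, compound 2 or compound 3 can be read. The compounds shown leave open how these bromophenyl and cyanophenyl groups rank against one another, with every value at one limit: the limit of > 25000 nM in this assay, at which 4 of the 4 values shown sit.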